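The source may hold more compounds than are shown below. What is called first, only, known or untested is meant among the compounds shown, and "the series" means these compounds.

Measured so far in a functional assay on SGC-7901 cells (Homo sapiens) for antiproliferative activity, read by MTT assay, with a stated time of 72 h; on this read-out higher numbers stand for weaker inhibition and lower numbers for stronger inhibition: compound 1 `C#Cc1cccc(Nc2ncnc3c(OC)c(OC)c(OC)cc23)c1` gives 5820 nM and compound 2 `COc1cc2c(Nc3ccc(B(O)O)cc3)ncnc2c(OC)c1OC` gives 434 nM. Compound 3 `COc1cc2c(Nc3cccc(F)c3F)ncnc2c(OC)c1OC` sits at the limit of > 30000 nM in this assay, at which 1 of the 3 values shown sits; its value, > 30000 nM, is a limit of the assay and not a number.

Of the two numbers, compound 1 has the higher one and compound 2 the lower, a gap beyond the scatter. Compound 4 `COc1cc2c(Nc3ccc(F)c(Cl)c3)ncnc2c(OC)c1OC` differs from compound 1 by 3-chloro-4-fluorophenyl in place of 3-ethynylphenyl on a nitrogen on an aromatic ring. Going by the values given here, the one measured step that bears on this is an at least 5.1-fold higher number from compound 1 to compound 3 (0.71 log units; beyond the scatter), where another halogen-bearing phenyl replaced the same 3-ethynylphenyl and the number moved to the limit. A weakening of similar kind is therefore expected here. Compound 4 is expected to give 15000 nM, with a range from 3000 nM to 60000 nM. Compound 4 is thus expected to show a 2.6-fold higher number from compound 1 to compound 4 (0.41 log units; beyond the scatter).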

Compound 4, half-maximal inhibitory concentration: 5420 nM
Beside the measured number, compound 4's estimate is 2.8-fold (0.44 log units) above it, and the stated range covers the measured number.
By their numbers in this assay, from the lowest: compound 2; then compounds 4 and 1 (each within the scatter of the next). At a limit, above all of these: compound 3.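

In this assay this change gives a 1.1-fold lower number from compound 1 to compound 4 (0.03 log units; within the scatter) and so shows that a halogen-bearing phenyl on this nitrogen can stand level with 3-ethynylphenyl. Which halogens the ring carries, and where, does matter here, with an at least 5.5-fold lower number from compound 3 to compound 4 (0.74 log units; beyond the scatter) for two halogen-bearing phenyls. Compound 3 stands at a limit of the assay: the limit of > 30000 nM in this assay, at which 1 of the 4 values shown sits.

Still open, as far as these compounds go, is whether the chlorine or the fluorine of 3-chloro-4-fluorophenyl accounts for that difference. Also open, from the compounds shown here alone, is whether an amine or a carboxylic acid on this phenyl ring would keep the number level or shift it.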